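Shortening the chain on compound 2

A few compounds are considered here, and "the series" means these few. Any claim that something is new, unique, unknown or untested is made for them only; others in the source may bear on it.

Compound 1 `COc1cc(Nc2nc(N[C@H]3CC[C@H](N)CC3)nc3c2ncn3CCC(C)C)cc(OC)c1`: 140 nM
Compound 2 `CCCCCCn1cnc2c(Nc3cc(OC)cc(OC)c3)nc(N[C@H]3CC[C@H](N)CC3)nc21`: 380 nM

In a functional assay on EOL1 cells (Homo sapiens) for inhibition, read by fluorescence, with a stated time of 72 h (on this read-out lower numbers stand for stronger inhibition of growth and higher numbers for weaker inhibition of growth), compound 2 has the higher of the two numbers, at 380 nM, so it is the weaker growth inhibitor of this pair. Compound 3 `CCCCn1cnc2c(Nc3cc(OC)cc(OC)c3)nc(N[C@H]3CC[C@H](N)CC3)nc21` differs from compound 2 in one place: hydrogen in place of ethyl on a saturated chain carbon, four bonds along the chain from an aromatic nitrogen. This is hydrogen in place of ethyl on a saturated chain carbon, four bonds along the chain from an aromatic nitrogen.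

Going by the values given here, only one measured step bears on this change: a 2.7-fold higher number from compound 1 to compound 2 (0.43 log units; beyond the scatter). It is modest, and it also alters the chain on that aromatic nitrogen, though the structural change is not the same. Among the compounds with values here, a single step is thin evidence, so a modest move towards a lower number is expected, no larger than that step. The expected change is a 1.7-fold lower number from compound 2 to compound 3 (0.24 log units; within the scatter). For compound 3 the estimate is 220 nM, with a range of 90 nM to 500 nM.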

Compound 3, concentration for 50% growth inhibition: 370 nM
Beside the measured number, compound 3's estimate is 1.7-fold (0.23 log units) below it, and the stated range covers the measured number.
By their numbers in this assay, from the lowest: compound 1; then compounds 3 and 2 (each within the scatter of the next).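

Removing the ethyl leaves the number in this assay essentially unmoved (a 1.0-fold lower number from compound 2 to compound 3 (0.01 log units; within the scatter)), so this part of the straight chain makes no difference that can be read on this read-out. The other new comparison points elsewhere: hydrogen in place of methyl on the saturated chain carbon bound to two saturated chain carbons gives a modest shift (a 2.6-fold higher number from compound 1 to compound 3 (0.42 log units; beyond the scatter)), beyond the scatter. Among these three compounds, then, the branched chain of compound 1 stands apart, while the straight chains of compound 2 and compound 3 cannot be told apart, and no measurement at hand explains this.

Going by these compounds, whether the number stays level with a still shorter propyl or methyl group on that aromatic nitrogen remains open. So does the effect of a chain carrying an amine or a carboxylic acid.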